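A few compounds are considered here, and "the series" means these few. Any claim that something is new, unique, unknown or untested is made for them only; others in the source may bear on it.

Of the compounds shown here, two anchor the series so far. In a functional assay on HeLa cells (Homo sapiens) for antiproliferative activity, read by CCK-8 assay, with a stated time of 72 h (a higher number here means a weaker inhibitor of growth, a lower number a stronger inhibitor of growth), compound 1 (`CCC1C(=O)N(C)c2cnc(Nc3ccc(S(=O)(=O)NC)cc3)nc2N1c1ccn(C)n1`) gives 2200 nM. Among the measured compounds shown here, compound 2 (`CCC1C(=O)N(C)c2cnc(-n3ccc4cc(F)ccc43)nc2N1c1ccn(C)n1`) is reported as "not active" (no number reported), with no number attached, so it has no exact place on the scale and no step can be computed from it. Compound 3 (`CCC1C(=O)N(C)c2cnc(-n3ccc4cc(C(=O)NC5CCCC5)ccc43)nc2N1c1ccn(C)n1`) keeps the core of compound 2 and changes one substituent: cyclopentylcarbamoyl in place of fluoro on an aromatic carbon. For the measured compounds named here, no measured pair shows what such a change does. A step toward stronger growth inhibition in this assay is expected, large enough to yield a number, though another result without a number remains possible. Going by the values given here, the only number available for comparison is that of compound 1, 2200 nM. For compound 3 the expected value is 3000 nM, with an estimated range of 400 nM to 20000 nM.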

Compound 3, concentration for 50% growth inhibition: 27400 nM
For compound 3 the middle estimate is 9.1-fold (0.96 log units) below the measured one; measured number above the stated range.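

In this assay compound 3 gives 27400 nM and compound 2 carries no number, so no step can be read between them. Going by these compounds, what replacing fluoro with cyclopentylcarbamoyl does to growth inhibition stays open. No supporting evidence bears on this result.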